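The compounds below may be only part of what the source reports. "The series", "measured", "known", "first", "only" and "open" are said of these compounds alone.

Measured so far:
compound 1 `O=C(CSc1nc(Nc2ccccc2)c2ccccc2n1)Nc1ccc(Cl)cc1Cl`: 9110 nM
compound 2 `C=CC(=O)Nc1cccc(NC(=O)CSc2nc(Nc3ccccc3Cl)c3ccccc3n2)c1`: 14400 nM

Both numbers come from a functional assay on PC-3 cells (Homo sapiens) for inhibition, read by MTT assay, with a stated time of 72 h; a higher number here means a weaker inhibitor, a lower number a stronger inhibitor. In this assay compound 1 gives 9110 nM and compound 2 gives 14400 nM. Compound 2 stands at the upper end of these two numbers, yet its gap to compound 1 lies within the usual scatter of repeated measurements, so the two compounds cannot be told apart here.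

Compound 3 `C=CC(=O)Nc1cccc(NC(=O)CSc2nc(Nc3ccc(F)c(Cl)c3)c3ccccc3n2)c1` has not yet been measured. It differs from compound 2 in one place: 3-chloro-4-fluorophenyl in place of 2-chlorophenyl on a nitrogen on an aromatic ring. Among the compounds with values here, no measured pair shows what this change does, so the size of the step is a guess. Compound 3 is expected to land close to compound 2 in this assay, with a 1.3-fold lower number from compound 2 to compound 3 (0.12 log units; within the scatter) a step expected to stay within the scatter, in no clear direction. Compound 3 is estimated at 11000 nM, in a range from 3500 nM to 35000 nM.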

Compound 3, half-maximal inhibitory concentration: > 50000 nM
Compound 3: no number, only a limit (the forecaster's own chance of this, stated with the estimate: 10%); at least 4.5-fold (0.65 log units) between middle value and limit.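

In this assay compound 3 gives > 50000 nM, which is a limit of the assay and not a number. This is the first readable step among these compounds, and it shows that the group on this nitrogen matters: 3-chloro-4-fluorophenyl in place of 2-chlorophenyl gives an at least 3.4-fold higher number from compound 2 to compound 3 (0.54 log units; beyond the scatter). The full size of this loss stays unknown, since the step is only a lower bound: the limit of > 50000 nM in this assay, at which 1 of the 3 values shown sits.

The change swaps one substituted ring for another, so the compounds shown cannot tell whether the added fluorine or the different chlorine placement accounts for the loss. Also open, on these data alone, is how a ring on this nitrogen carrying a methoxy group or an amine would behave, and compound 1 differs from both compounds in more than one place, so it cannot settle this.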